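2,4-Dichlorophenyl in place of 4-bromophenyl: an expected step

The compounds below may be only part of what the source reports. "The series", "measured", "known", "first", "only" and "open" are said of these compounds alone.

In a functional assay on HepG2 cells (Homo sapiens) for cytotoxicity, read by MTT assay, with a stated time of 24 h (a higher number here means a weaker inhibitor, a lower number a stronger inhibitor), compound 1 (`COc1cc(/C=C2\CN(C)C/C(=C\c3ccccc3F)C2=O)cc(OC)c1OC`) gives 670 nM and compound 2 (`COc1cc(/C=C2\CN(C)C/C(=C\c3ccc(Br)cc3)C2=O)cc(OC)c1OC`) gives 6800 nM as the higher of the two numbers. Among the compounds with values here, the single measured step is large: a 10-fold higher number from compound 1 to compound 2 (1.01 log units; beyond the scatter) with 4-bromophenyl in place of 2-fluorophenyl on a double-bonded chain carbon bound to a double-bonded ring carbon.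

Compound 3 (`COc1cc(/C=C2\CN(C)C/C(=C\c3ccc(Cl)cc3Cl)C2=O)cc(OC)c1OC`) is not yet measured and changes the same place, with 2,4-dichlorophenyl in place of 4-bromophenyl (2,4-dichlorophenyl in place of 4-bromophenyl on a double-bonded chain carbon bound to a double-bonded ring carbon). The name of its group shares the 2 of the 2-fluorophenyl in compound 1 at 670 nM and the 4 of the 4-bromophenyl in compound 2 at 6800 nM so only part of a 10-fold higher number from compound 1 to compound 2 (1.01 log units; beyond the scatter) is expected to return. Within the data shown here, no compound with a chlorine has been measured, and the expectation rests on this one step alone. The step expected in this assay is a 3.1-fold lower number from compound 2 to compound 3 (0.49 log units; beyond the scatter) toward a lower number, smaller than the measured one. For compound 3 the estimate is 2200 nM with an expected range from 700 nM to 6500 nM in this series.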

Compound 3, half-maximal inhibitory concentration: 8800 nM
Beside the measured number, compound 3's estimate is 4.0-fold (0.60 log units) below it; the measured number lies above the stated range.
By their numbers in this assay, from the lowest: compound 1; then compounds 2 and 3 (each within the scatter of the next).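

In this assay, 2,4-dichlorophenyl in place of 4-bromophenyl gives a 1.3-fold higher number from compound 2 to compound 3 (0.11 log units; within the scatter), so at this place on a double-bonded chain carbon bound to a double-bonded ring carbon, these two groups cannot be told apart, although one carries two chlorines and the other a single bromine. The 2 in the group's name does not by itself bring the number back toward that of compound 1: 2,4-dichlorophenyl in place of 2-fluorophenyl gives a 13-fold higher number from compound 1 to compound 3 (1.12 log units; beyond the scatter), which leaves compound 1 as the only one of the three set apart, with the lowest number in this assay. The data at hand give no measured basis for explaining either step.

Still open, as far as these compounds go, is whether the lower number of compound 1 goes with the fluorine, with the 2 in its group's name, or with the two together, and a 2-chlorophenyl or a 4-fluorophenyl group at this place would separate these readings. Also open is how the number responds to a phenyl ring carrying an amine or a carboxylic acid at this place, as all three groups shown carry only halogens.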